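The source may report more compounds than this note shows. Statements on the series, on what has been measured and on what is new or still open speak of the compounds shown alone.

Measured compounds:
compound 1 `C#CC(=O)N1C(c2ccc(C#N)cc2)SC[C@@H]1C(=O)OCC` gives 2600 nM in a functional assay on Huh-7 cells (Homo sapiens) for inhibition, read by sulforhodamine B assay; on this read-out higher numbers stand for weaker inhibition and lower numbers for stronger inhibition;
compound 2 `C#CC(=O)N1C(CCCC)SC[C@@H]1C(=O)OCC` gives 500 nM;
compound 3 `C#CC(=O)N1C(C(C)(C)C)SC[C@@H]1C(=O)OCC` gives 800 nM.

Compound 3 sits second highest of these three. Its nearest neighbour is compound 2, a step of a 1.6-fold higher number from compound 2 to compound 3 (0.20 log units; within the scatter). Compound 1, with its aryl group, gives the higher number, a gap beyond the scatter.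

Compound 4 `C#CC(=O)N1C(c2ccc(F)cc2)SC[C@@H]1C(=O)OCC` differs from compound 3 by 4-fluorophenyl in place of tert-butyl on a saturated ring carbon. Going by the values given here, no measured step covers this exact change; the only step measured, from one saturated chain to another, was a 1.6-fold higher number from compound 2 to compound 3 (0.20 log units; within the scatter), within the scatter. Compound 1 shows that an aryl group at this carbon gives a higher number than compound 3, so compound 4 is expected to move toward weaker inhibition, estimated at a 1.9-fold higher number from compound 3 to compound 4 (0.27 log units; within the scatter). Compound 4 is therefore estimated at 1500 nM, with a range from 600 nM to 4000 nM.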

Compound 4, half-maximal inhibitory concentration: 700 nM
Compound 4: the middle estimate sits 2.1-fold (0.33 log units) above what was measured; the range from low to high includes it.
By their numbers in this assay, from the lowest: compounds 2, 4 and 3 (each within the scatter of the next); then compound 1.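

In this assay, an aryl group on this saturated ring carbon does not by itself separate a compound from the saturated groups: 4-fluorophenyl in place of tert-butyl gives a 1.1-fold lower number from compound 3 to compound 4 (0.06 log units; within the scatter), and in place of butyl gives a 1.4-fold higher number from compound 2 to compound 4 (0.15 log units; within the scatter). The gap seen for compound 1 instead follows the group on the aromatic carbon, as fluoro in place of cyano gives a 3.7-fold lower number from compound 1 to compound 4 (0.57 log units; beyond the scatter). Nothing available explains this difference. The compounds shown leave open whether an amine or a carboxylic acid on that aromatic carbon would track compound 4 or compound 1.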